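The compounds below may be only part of what the source reports. "The series", "measured", "known", "first", "only" and "open" are said of these compounds alone.

Measured in a functional assay on HT-29 cells (Homo sapiens) for cytotoxicity, read by MTT assay, with a stated time of 72 h; a higher number here means a weaker inhibitor, a lower number a stronger inhibitor:
compound 1 `COc1ccc(C(=O)c2cc(OC)c(OC)c(OC)c2)cc1NC(=O)/C=C/c1cc(OC)c(OC)c(OC)c1` gives 3100 nM
compound 2 `COc1cccc(/C=C/C(=O)Nc2cc(C(=O)c3cc(OC)c(OC)c(OC)c3)ccc2OC)c1` gives 1900 nM
compound 3 `COc1ccc(C(=O)c2cc(OC)c(OC)c(OC)c2)cc1NC(=O)/C=C/c1ccc(F)cc1` gives 1800 nM

Compound 3 holds the lowest of the three numbers in this assay, but both steps that reach it, a 1.1-fold lower number from compound 2 to compound 3 (0.02 log units; within the scatter) and a 1.7-fold lower number from compound 1 to compound 3 (0.24 log units; within the scatter), sit within the scatter, so no order among the three is established. Compound 4 `COc1cc(/C=C/C(=O)Nc2cc(C(=O)c3cc(OC)c(OC)c(OC)c3)ccc2OC)ccc1F` is the next member; the change is methoxy in place of hydrogen on an aromatic carbon. Going by the values given here, the steps that alter this same ring, a 1.6-fold lower number from compound 1 to compound 2 (0.21 log units; within the scatter), a 1.7-fold lower number from compound 1 to compound 3 (0.24 log units; within the scatter) and a 1.1-fold lower number from compound 2 to compound 3 (0.02 log units; within the scatter), all stay within the scatter, so swapping methoxy-bearing and fluoro-bearing rings has not moved the number so far. The expected step is no change at the digits printed from compound 3 to compound 4 (within the scatter), that is, nothing beyond the scatter. Compound 4 is accordingly estimated at 1800 nM, within 900 nM to 3600 nM.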

Compound 4, half-maximal inhibitory concentration: 7700 nM
For compound 4 the middle estimate is 4.3-fold (0.63 log units) below the measured one; measured number above the stated range.
By their numbers in this assay, from the lowest: compounds 3, 2 and 1 (each within the scatter of the next); then compound 4.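

In this assay, going by these compounds alone, this ring position, ortho to a fluoro group, gives the first change beyond the scatter: methoxy in place of hydrogen produces a 4.3-fold higher number from compound 3 to compound 4 (0.63 log units; beyond the scatter) and the matching fluoro in place of hydrogen produces a 4.1-fold higher number from compound 2 to compound 4 (0.61 log units; beyond the scatter) in the series. Compound 2 and compound 3, each with one of these groups, stay within the scatter of each other, so the higher number appears only with both on the ring, and a 2.5-fold higher number from compound 1 to compound 4 (0.40 log units; beyond the scatter) sets this ring apart from 3,4,5-trimethoxyphenyl too. No measurement here bears on the cause. As far as these compounds go, whether a hydroxy or ethoxy group in place of this methoxy also raises the number stays open, as does whether chloro in place of the fluoro does.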